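Removing the methoxy groups from a cinnamamide

A few compounds are considered here, and "the series" means these few. Any claim that something is new, unique, unknown or untested is made for them only; others in the source may bear on it.

Compound 1, `O=C(Nc1cc(Sc2ncn[nH]2)c(O)c2ccccc12)c1ccc([N+](=O)[O-])cc1`, in a functional assay on MDA-MB-231 cells (Homo sapiens) for antiproliferative activity, read by MTT assay, with a stated time of 48 h; a higher number here means a weaker inhibitor, a lower number a stronger inhibitor: > 100000 nM (a limit of the assay).
Compound 2, `COc1ccc(/C=C/C(=O)Nc2cc(Sc3ncn[nH]3)c(O)c3ccccc23)cc1OC`, in this assay: 52500 nM.

Compound 1 gives only a limit in this assay, > 100000 nM, and no number. Among the compounds with values here, compound 2 is thus the one compound with a measured number here, its value being 52500 nM. What compound 1 shows instead is the limit of > 100000 nM in this assay, at which 1 of the 2 values shown sits.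

Compound 3, `O=C(/C=C/c1ccccc1)Nc1cc(Sc2ncn[nH]2)c(O)c2ccccc12`, carries phenyl in place of 3,4-dimethoxyphenyl on a double-bonded chain carbon bound to a double-bonded chain carbon. No step between two measured compounds is shown for this kind of change, so the account rests on compound 2 alone. The expectation for compound 3 is a step of a 1.3-fold higher number from compound 2 to compound 3 (0.12 log units; within the scatter), toward weaker inhibition, of a size that may not exceed the scatter. Compound 3 is expected to give about 70000 nM, within 25000 nM to 200000 nM, with a real chance that only a limit is reported.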

Compound 3, half-maximal inhibitory concentration: > 100000 nM
Compound 3 was reported as a limit (the forecaster's own chance of this, stated with the estimate: 35%); middle value at least 1.4-fold (0.15 log units) from the limit.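

In this assay, phenyl in place of 3,4-dimethoxyphenyl on a double-bonded chain carbon bound to a double-bonded chain carbon gives an at least 1.9-fold higher number from compound 2 to compound 3 (0.27 log units; that floor lies within the scatter). On these data alone, compound 3 gives only a limit, so this step is a floor and its true size is unknown; the data therefore do not establish that the 3,4-dimethoxyphenyl group gives stronger inhibition than phenyl. The step between compound 1 and compound 3 cannot be read, and compound 2 remains the only compound with a measured number: the limit of > 100000 nM in this assay, at which 2 of the 3 values shown sit.

As far as these compounds go, it remains open whether a single methoxy group, a hydroxyl group or a fluorine atom on the phenyl ring would give a measured number. From the compounds shown here alone, it also remains open whether the two methoxy groups of compound 2 contribute equally, or whether one alone would match its value.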